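Changing one halogenated phenyl for another on the shared core

The source may hold more compounds than are shown below. What is called first, only, known or untested is meant among the compounds shown, and "the series" means these compounds.

Compound 1 `CCCn1c(=O)[nH]c2nc(-c3ccc(S(=O)(=O)N4CCN(c5cccc(Cl)c5)CC4)cc3)[nH]c2c1=O` carries a 3-chlorophenyl group on an amine nitrogen in a ring. In an assay on CHO cells for displacement of a labelled ligand from adenosine receptor A1 (Homo sapiens), read by scintillation counting, with a stated time of 90 min, tested at 1 uM, in the presence of a further agent that is not named here (on this read-out higher numbers stand for more inhibition at the one concentration tested (going by the name of the read-out) and lower numbers for less inhibition), compound 1 gives 21%, the second highest of the three numbers recorded. Compound 2 `CCCn1c(=O)[nH]c2nc(-c3ccc(S(=O)(=O)N4CCN(c5ccccc5F)CC4)cc3)[nH]c2c1=O` gives 13% in this assay. Compound 3 `CCCn1c(=O)c2[nH]c(-c3ccc(S(=O)(=O)N4CCN(c5ccc(Cl)cc5)CC4)cc3)nc2n(CC)c1=O` differs from compound 1 in several places, not in one. In this assay compound 3 gives 24%. The values of compound 1 and compound 3 lie within the scatter of each other. Going by the values given here, the single one-place step recorded is a number 8 percentage points lower from compound 1 to compound 2 (within the scatter).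

Compound 4 `CCCn1c(=O)[nH]c2nc(-c3ccc(S(=O)(=O)N4CCN(c5ccc(I)cc5)CC4)cc3)[nH]c2c1=O` has not yet been measured. It differs from compound 1 as follows: 4-iodophenyl in place of 3-chlorophenyl on an amine nitrogen in a ring. Among the compounds with values here, the only measured step that bears on this change, a number 8 percentage points lower from compound 1 to compound 2 (within the scatter), also replaced the aryl group on the same ring nitrogen and stayed within the scatter, so no step beyond the scatter is expected here either. Compound 4 is therefore expected to give about 20% in this assay, within a range of 5% to 35%. That amounts to an expected step of a number 1 percentage points lower from compound 1 to compound 4 (within the scatter).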

Compound 4, a percentage reported as inhibition, at one concentration (the size of the read-out at that concentration, not a potency): 24%
Estimate against measurement, compound 4: 4 percentage points below; measured number inside the range.
By their numbers in this assay, from the lowest: compounds 2, 1, 3 and 4 (each within the scatter of the next, the first and the last beyond it).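

In this assay, the aryl group on the ring nitrogen now yields a step beyond the scatter, a number 11 percentage points higher from compound 2 to compound 4 (beyond the scatter) with 4-iodophenyl in place of 2-fluorophenyl. The exchange of 3-chlorophenyl for 4-iodophenyl amounts to a number 3 percentage points higher from compound 1 to compound 4 (within the scatter) and so does not separate these two groups, which means that this position has so far shown only a modest step, and only between compound 2 and compound 4. Nothing measured here explains that step.

The compounds shown leave open whether a plain phenyl or a benzyl group on this ring nitrogen would sit with compound 2 or with compound 4. They also leave open whether the halogen or its place on the phenyl ring carries the step, as compound 2 and compound 4 differ in both.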